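Chloro to Nitro on a Shared Core: Expecting Compound 3

The source may report more compounds than this note shows. Statements on the series, on what has been measured and on what is new or still open speak of the compounds shown alone.

Compound 1 `CCn1c(/C=C2/C(=O)Nc3ccc(F)cc32)nc2ccccc21` gives > 50000 nM in a functional assay on MCF7 cells (Homo sapiens) for cytotoxicity, read by MTT assay, with a stated time of 48 h; a higher number here means a weaker inhibitor, a lower number a stronger inhibitor.
Compound 2 `CCn1c(/C=C2/C(=O)Nc3ccc(Cl)cc32)nc2ccccc21` gives > 50000 nM in this assay.

Both values are limits of the assay, not numbers. The step that the two limits leave unreadable from compound 1 to compound 2 therefore cannot be read. Going by these compounds, compound 2 stands at the limit of > 50000 nM in this assay, at which 2 of the 2 values shown sit, so its true value is unknown beyond that.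

Compound 3 `CCn1c(/C=C2/C(=O)Nc3ccc([N+](=O)[O-])cc32)nc2ccccc21` differs from compound 2 by nitro in place of chloro on an aromatic carbon. Among the compounds with values here, no measured step shows how nitro compares with chloro here, and the only step between measured compounds is unreadable, so no change beyond the scatter is expected; the expected step is a step that the limit leaves unreadable from compound 2 to compound 3. Compound 3 is estimated at 60000 nM, between 10000 nM and 200000 nM, most likely again only a limit.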

Compound 3, half-maximal inhibitory concentration: > 50000 nM
Compound 3 was reported as a limit; the forecaster's own chance of this, stated with the estimate: 75%; the middle value lies beyond the limit too.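

Compound 1, compound 2 and compound 3 are all limits of the assay rather than numbers, so no step among them can be read: the limit of > 50000 nM in this assay, at which 3 of the 3 values shown sit.

Going by these compounds, how strongly any of the three acts on these cells stays open.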